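Exchanging bromo for methoxy in compound 2

The compounds below may be only part of what the source reports. "The series", "measured", "known", "first", "only" and "open" are said of these compounds alone.

In a functional assay on MCF7 cells (Homo sapiens) for cytotoxicity, read by MTT assay, with a stated time of 48 h (a lower number here means a stronger inhibitor, a higher number a weaker inhibitor), compound 2 (`CCN(CC)C(=S)SC(CC(=O)c1ccc(Br)cc1)c1ccc(OC)cc1`) gives 5000 nM, within the scatter of compound 1 (`CCN(CC)C(=S)SC(CC(=O)c1ccc(OC)cc1)c1ccccc1`) at 4500 nM, while compound 3 (`CCN(CC)C(=S)SC(CC(=O)c1ccc(Br)cc1)c1ccc(F)cc1`) gives 1000 nM. Compound 4 (`CCN(CC)C(=S)SC(CC(=O)c1ccc(OC)cc1)c1ccc(OC)cc1`) differs from compound 2 by methoxy in place of bromo on an aromatic carbon. Within the data shown here, no measured step makes this exchange. Among the measured compounds shown here, the one measured step, a 5.0-fold lower number from compound 2 to compound 3 (0.70 log units; beyond the scatter), is modest and lies elsewhere in the molecule, so it bears only indirectly. Compound 4 receives methoxy where compound 1 carries it, and compound 1 gives 4500 nM. No change beyond the scatter is therefore expected, and the estimated step is a 1.1-fold lower number from compound 2 to compound 4 (0.05 log units; within the scatter). For compound 4 the estimated value is 4500 nM, with an expected range of 1800 nM to 11000 nM.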

Compound 4, half-maximal inhibitory concentration: 800 nM
Estimate against measurement, compound 4: 5.6-fold (0.75 log units) above; measured number below the stated range.
By their numbers in this assay, from the lowest: compounds 4 and 3 (each within the scatter of the next); then compounds 1 and 2 (each within the scatter of the next).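

Among these compounds, the exchange of 4-bromophenyl to 4-methoxyphenyl gives a 6.3-fold lower number from compound 2 to compound 4 (0.80 log units; beyond the scatter) in this assay, so this position, which no earlier step had tested, does affect the number. Methoxy in place of hydrogen on an aromatic carbon elsewhere in the molecule also counts, with a 5.6-fold lower number from compound 1 to compound 4 (0.75 log units; beyond the scatter). Nothing available accounts for either step. Going by these compounds, whether the gain is particular to methoxy remains open, since only bromo and methoxy are compared at this position. On these data alone, how an amine, a carboxylic acid or a longer alkoxy chain would fare there also remains unknown.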